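Ester-linked piperidine amide replaces the anilide side chain

The source may report more compounds than this note shows. Statements on the series, on what has been measured and on what is new or still open speak of the compounds shown alone.

Two lignan-type lactones sharing a common core have been tested in an ADME assay on HeLa cells (Homo sapiens) for cytotoxicity, read by MTT assay; on this read-out lower numbers stand for stronger inhibition and higher numbers for weaker inhibition. Compound 1 `COc1ccc(C[C@H]2COC(=O)[C@@H]2Cc2ccc(OCc3cn(Cc4ccc(Cl)cc4)nn3)c(OC)c2)cc1OC` gives 242000 nM in this assay. Compound 2 `COc1ccc(C[C@H]2COC(=O)[C@@H]2Cc2ccc(OCC(=O)Nc3ccc(C)cc3)c(OC)c2)cc1OC` gives 228000 nM in this assay. Among the two numbers known, compound 2 has the lowest, yet its nearest neighbour, compound 1, sits within the usual scatter of it, so no order between them can be read from these values; both lie far into the weak range of this assay.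

Compound 3 `COc1ccc(C[C@H]2COC(=O)[C@@H]2Cc2ccc(OC(=O)CCC(=O)N3CCCCC3)c(OC)c2)cc1OC` has not yet been measured in this assay. Within the data shown here, it is derived from compound 2 by a single exchange at the side chain: a group of 12 heavy atoms (9 carbon, 1 nitrogen, 2 oxygen; one six-membered non-aromatic ring with 1 hetero atom) in place of a group of 11 heavy atoms (9 carbon, 1 nitrogen, 1 oxygen; one six-membered aromatic ring of carbon only), on an oxygen on an aromatic ring No step between measured compounds is available for a change of this kind, so the expectation rests only on the two values known, which are close to each other.

A step of at most modest size, in either direction or none beyond the scatter, is expected for the change from compound 2 to compound 3, a 1.0-fold higher number from compound 2 to compound 3 (0.00 log units; within the scatter). Compound 3 is therefore estimated at 230000 nM in this assay, with a range from 100000 nM to 500000 nM.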

Compound 3, half-maximal inhibitory concentration: 128000 nM
The estimate for compound 3 lay 1.8-fold (0.25 log units) above the measured number; the measured number falls inside the stated range.
By their numbers in this assay, from the lowest: compounds 3, 2 and 1 (each within the scatter of the next).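

In this assay, among these compounds, the step at this position is a 1.8-fold lower number from compound 2 to compound 3 (0.25 log units; within the scatter), and it is the first step between measured compounds that differ in one place. On an oxygen on an aromatic ring, the ((4-methylphenyl)carbamoyl)methyl group, with its six-membered aromatic ring of carbon only and its hydrogen-bond donor, gives way to a group with a six-membered non-aromatic ring with 1 hetero atom and 0 hydrogen-bond donors, and the two numbers cannot be told apart, so this large exchange of the side chain leaves the read-out within the scatter. Nothing measured here offers an explanation for this result.

Since the group exchanged differs in its link to the oxygen and in its ring together, compound 2 and compound 3 cannot show what either part contributes by itself. On these data alone, it also stays open whether a carboxylic acid, a morpholine amide or a longer chain on this oxygen would give a step beyond the scatter in this assay or would leave the number as far into the weak range as these.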